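The compounds below may be only part of what the source reports. "The series", "measured", "known", "first", "only" and "open" are said of these compounds alone.

In a functional assay on MDA-MB-231 cells (Homo sapiens) for antiproliferative activity, read by MTT assay, with a stated time of 48 h (a higher number here means a weaker inhibitor, a lower number a stronger inhibitor), compound 1 `C=CS(=O)(=O)N1CCN(c2ncnc3sc(-c4ccccc4)cc23)CC1` gives 54200 nM. Compound 3 `C=CS(=O)(=O)N1CCN(c2ncnc3sc(-c4ccnc(Cl)c4)cc23)CC1` gives 27700 nM and compound 2 `C=CS(=O)(=O)N1CCN(c2ncnc3sc(-c4ccc(C(F)(F)F)cc4)cc23)CC1` gives 6410 nM, so compound 1 shares the weak end of these numbers with compound 3.

Compound 4 `C=CS(=O)(=O)N1CCN(c2ncnc3sc(-c4ccc(OC)nc4)cc23)CC1` has not yet been measured. It carries 6-methoxypyridin-3-yl in place of phenyl on an aromatic carbon, next to the ring sulfur (6-methoxypyridin-3-yl in place of phenyl on an aromatic carbon).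

Two measured changes touch this same group. Adding trifluoromethyl gave an 8.5-fold lower number from compound 1 to compound 2 (0.93 log units; beyond the scatter), a modest step. Putting 2-chloropyridin-4-yl in place of phenyl gave a 2.0-fold lower number from compound 1 to compound 3 (0.29 log units; within the scatter). That second step is the closer guide, as compound 3 also has a pyridine ring in this place. Among the compounds with values here, no measured compound carries a methoxy group, so the data cannot say what that group adds.

The expected change is small, toward a lower number and no larger than the scatter, and the estimated step is a 1.8-fold lower number from compound 1 to compound 4 (0.26 log units; within the scatter). For compound 4 the estimated value is 30000 nM, with an expected range of 10000 nM to 80000 nM.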

Compound 4, half-maximal inhibitory concentration: 9270 nM
The estimate for compound 4 lay 3.2-fold (0.51 log units) above the measured number; the measured number lies below the stated range.
By their numbers in this assay, from the lowest: compounds 2 and 4 (each within the scatter of the next); then compounds 3 and 1 (each within the scatter of the next).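

In this assay, moving from a plain phenyl to 6-methoxypyridin-3-yl on this aromatic carbon gives a 5.8-fold lower number from compound 1 to compound 4 (0.77 log units; beyond the scatter), so this position can respond clearly to a pyridine-containing group. The pyridine ring alone does not settle the number, as swapping one substituted pyridine for the other gives a 3.0-fold lower number from compound 3 to compound 4 (0.48 log units; beyond the scatter), and 6-methoxypyridin-3-yl also matches the trifluoromethyl-bearing phenyl, with a 1.4-fold higher number from compound 2 to compound 4 (0.16 log units; within the scatter). No measurement here explains why these groups differ.

The compounds shown do not separate the contribution of the methoxy group from that of the ring nitrogen, which a phenyl ring bearing methoxy or a pyridin-3-yl ring without it could do. They also leave open how an amine or a carboxylic acid on this ring would read.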